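The source may report more compounds than this note shows. Statements on the series, on what has been measured and on what is new or still open speak of the compounds shown alone.

The measured compounds in a functional assay on PC-3 cells (Homo sapiens) for cytotoxicity, read by MTT assay; a higher number here means a weaker inhibitor, a lower number a stronger inhibitor:

compound 1 `COc1cc(/C=C/C(=O)c2sc(Nc3ccccc3C)nc2C)cc(OC)c1OC` gives > 25000 nM, which is a limit of the assay and not a number.
compound 2 `COc1ccc(/C=C/C(=O)c2sc(Nc3ccc(Cl)cc3)nc2C)cc1` gives > 25000 nM, likewise a limit of the assay.
compound 3 `Cc1nc(Nc2ccccc2)sc1C(=O)/C=C/c1ccc(Cl)cc1` gives > 25000 nM, likewise a limit of the assay.

Compound 1 stands where every measured value stands: at the limit of > 25000 nM in this assay, at which 3 of the 3 values shown sit. For the measured compounds named here, no number is known for it, only that limit, and the same holds for compound 2 and for compound 3, so no step between measured compounds can be sized and no ordering among the three can be drawn.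

Compound 4 `COc1cc(/C=C/C(=O)c2sc(Nc3ccc(Cl)cc3)nc2C)cc(OC)c1OC` differs from compound 1 in one place: 4-chlorophenyl in place of 2-methylphenyl on a nitrogen on an aromatic ring. Compound 2 already carries the (4-chlorophenyl)amino group and sits at the limit. Going by the values given here, nothing among the measured compounds suggests that this change moves the value off the limit. The step from compound 1 to compound 4 is therefore expected to be none beyond the scatter, a step that the limit leaves unreadable from compound 1 to compound 4. Compound 4 is expected to give 40000 nM in this assay, within 15000 nM to 150000 nM, and most likely to be reported again only as a limit.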

Compound 4, half-maximal inhibitory concentration: > 25000 nM
Compound 4 was reported as a limit; the forecaster's own chance of this, stated with the estimate: 85%; the middle value lies beyond the limit too.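

No step can be read from compound 1 to compound 4, because both are reported only as a limit of the assay and not as a number: the limit of > 25000 nM in this assay, at which 4 of the 4 values shown sit.

The compounds shown leave open whether 4-chlorophenyl in place of 2-methylphenyl changes the value at all, and what structure would bring a value off the limit.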